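The source may hold more compounds than are shown below. What is called first, only, known or untested is meant among the compounds shown, and "the series" means these compounds.

Compound 1 `CCCn1c(=O)c2nc(C3CCCC3C(=O)O)[nH]c2n(CCC)c1=O`: 100 nM; 140 nM (2 entries) in a functional assay for antagonist activity at adenosine receptor A1 (Homo sapiens); a higher number here means a weaker inhibitor, a lower number a stronger inhibitor. Compound 2 `CCCn1c(=O)c2nc(C3=C(C(=O)O)CCC3)[nH]c2n(CCC)c1=O`: > 10000 nM in this assay.

For compound 1, the several entries of compound 1 in this assay, 100 nM; 140 nM (2 entries) agree with each other. For compound 2 only a limit is known: in this assay compound 2 reaches > 10000 nM, which is the limit of > 10000 nM in this assay, at which 1 of the 2 values shown sits. Compound 3 `CCCn1c(=O)c2nc(C3CCC3C(=O)O)[nH]c2n(CCC)c1=O` carries 2-carboxycyclobutyl in place of 2-carboxycyclopent-1-en-1-yl on an aromatic carbon. Within the data shown here, no measured step covers this change, and compound 2 gives no number from which to count; compound 1, however, shows what an acid on a ring of this kind can do. Compound 3 is therefore expected to come in well below the limit of compound 2, with an at least 33-fold lower number from compound 2 to compound 3 (1.52 log units; beyond the scatter) as the estimated step. Compound 3 is estimated at 300 nM, within a range from 60 nM to 3000 nM.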

Compound 3, inhibition constant: 660 nM
Beside the measured number, compound 3's estimate is 2.2-fold (0.34 log units) below it, within the range that was stated.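

Putting 2-carboxycyclobutyl in place of 2-carboxycyclopent-1-en-1-yl on this aromatic carbon gives an at least 15-fold lower number from compound 2 to compound 3 (1.18 log units; beyond the scatter) in this assay. The step shows that a ring carrying the acid at this place can return from the limit reached by compound 2, even with the ring reduced to four members. Because compound 2 stands only at a limit, the step's full size stays unknown: the limit of > 10000 nM in this assay, at which 1 of the 3 values shown sits.

The compounds shown leave open whether the acid itself is needed, as an amide or a hydroxymethyl group in its place would test. They also leave open how a six-membered ring carrying the carboxylic acid would compare.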